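The compounds below may be only part of what the source reports. "The series", "measured", "known", "first", "only" and "open" are said of these compounds alone.

Compound 2, `CC1=C(C(=O)Nc2ccc(Br)cc2)C(c2ccc(Cl)cc2Cl)N=C(SCc2ccccc2)N1`, and compound 1, `CC1=C(C(=O)Nc2ccc(F)cc2)C(c2ccc([N+](=O)[O-])cc2)N=C(SCc2cccc(Cl)c2)N1`, share the same core and have both been tested in a functional assay on the whole organism (artery, strain albino) with Rattus norvegicus as the target, with a stated time of 300 min, at a dose of 10 mg/kg by the oral route; on this read-out lower numbers stand for less inhibition and higher numbers for more inhibition at the one dose given (going by the name of the read-out). In that assay compound 2 gives 22.1%, and compound 1 gives 18.5%; these two numbers lie within the scatter of each other, so neither can be set apart from the other on the evidence at hand. Going by the values given here, no pair of measured compounds differs in a single place, so nothing is yet known about how any one change moves this read-out. Compound 3, `CC1=C(C(=O)Nc2ccc(Br)cc2)C(c2ccc(Cl)cc2Cl)N=C(SCc2ccc(F)cc2)N1`, has not yet been measured; it differs from compound 2 by fluoro in place of hydrogen on an aromatic carbon. The change turns benzyl into 4-fluorobenzyl and touches nothing else. Among the compounds with values here, with no measured step to lean on, the step from compound 2 to compound 3 is expected to be a number 0.1 percentage points lower from compound 2 to compound 3 (within the scatter), that is, no movement beyond the scatter. Compound 3 is therefore estimated at 22%, with a range from 10% to 34%.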

Compound 3, a percentage reported as inhibition, in the whole organism at one dose (the size of the read-out at that dose, not a potency): 38.5%
For compound 3 the middle estimate is 16.5 percentage points below the measured one; the whole stated range lies below it.
By their numbers in this assay, from the lowest: compounds 1 and 2 (each within the scatter of the next); then compound 3.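

Turning benzyl into 4-fluorobenzyl gives, in this assay, a number 16.4 percentage points higher from compound 2 to compound 3 (beyond the scatter). This single pair shows that the read-out responds to a change at this aromatic carbon, para to a large group: one fluoro in place of hydrogen, with nothing else altered, is enough to move it beyond the scatter. Nothing measured here bears on why the step occurs.

On these data alone, whether this rise belongs to fluoro in particular, or would also follow from another group on the same carbon, such as methoxy or trifluoromethyl, remains open. Also open, as far as these compounds go, is whether the step carries over to compounds with different groups elsewhere on the shared core, since it rests on a single pair.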